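Benzyl for propyl on an amino side chain

The source may hold more compounds than are shown below. What is called first, only, known or untested is meant among the compounds shown, and "the series" means these compounds.

Of the compounds shown here, three sharing one core have been tested in an in vitro assay on HEK-tsA201 cells for antagonist activity at Neuronal acetylcholine receptor; alpha4/beta2 (Homo sapiens), read by fluorescence and calcium flux; a higher number here means a weaker inhibitor, a lower number a stronger inhibitor. Compound 1 `C#CCOc1ccc(C(=O)Nc2cccc(C)n2)cc1` gives 19400 nM. Compound 2 `C=CCOc1ccc(C(=O)Nc2cccc(CC)n2)cc1` gives 20500 nM. Compound 3 `CCCNc1cccc(NC(=O)c2ccc(OCCC)cc2)n1` gives 15400 nM, the lowest of the three numbers, yet its gaps to compound 1 and to compound 2 both lie within the scatter of this assay, so the three compounds cannot be told apart on these numbers.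

Compound 4 `CCCOc1ccc(C(=O)Nc2cccc(NCc3ccccc3)n2)cc1` has not yet been measured. It differs from compound 3 in one place: phenyl in place of ethyl on a saturated chain carbon bound to a nitrogen on an aromatic ring. Within the data shown here, no pair of measured compounds differs in a single place, so no measured step shows how this kind of change moves the read-out. The three values at hand sit close together despite differences in both side chains, which gives no reason to expect a large movement in either direction. Compound 4 is therefore expected to come out near compound 3, as a step of a 1.1-fold lower number from compound 3 to compound 4 (0.04 log units; within the scatter) that stays within the scatter. The estimate for compound 4 is 14000 nM, with a range from 4500 nM to 45000 nM.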

Compound 4, half-maximal inhibitory concentration: > 100000 nM
Compound 4: no number, only a limit; the forecaster's own chance of this, stated with the estimate: 15%; middle value at least 7.1-fold (0.85 log units) from the limit.
By their numbers in this assay, from the lowest: compounds 3, 1 and 2 (each within the scatter of the next). At a limit, above all of these: compound 4.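

Going from propylamino to benzylamino on the shared core gives an at least 6.4-fold higher number from compound 3 to compound 4 (0.81 log units; beyond the scatter) in this assay, the only single-place change shown so far, and it lies beyond the scatter. Compounds 1, 2 and 3 could not be told apart, but this result shows that the read-out is not indifferent to every change at this amino side chain: phenyl in place of ethyl here gives a clearly weaker inhibitor. For compound 4, > 100000 nM is a limit and not a number: the limit of > 100000 nM in this assay, at which 1 of the 4 values shown sits.

The compounds shown do not tell whether a butylamino or a cyclohexylmethylamino group in place of propylamino would stay close to compound 3 or behave like benzylamino. From the compounds shown here alone, how a plain amino group would read in this place also remains open.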